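Biaryl in place of trifluoromethoxy on the sulfonyl arene

This account rests on a few compounds, and the source may have more. Where it says the series, first, only, none or still open, it means among the compounds named here.

Measured so far:
- compound 1 `COc1cc2nc(N3CCN(S(=O)(=O)c4ccc(C(F)(F)F)cc4)CC3)nc(N)c2cc1OC`: 27000 nM
- compound 2 `COc1ccc(S(=O)(=O)N2CCN(c3nc(N)c4cc(OC)c(OC)cc4n3)CC2)cc1`: 39000 nM
- compound 3 `COc1cc2nc(N3CCN(S(=O)(=O)c4ccc(OC(F)(F)F)cc4)CC3)nc(N)c2cc1OC`: 25000 nM

All three compounds share one core and differ only in the group on the aromatic carbon of the sulfonyl-bearing ring. In a functional assay on PC-3 cells (Homo sapiens) for inhibition (a lower number here means a stronger inhibitor, a higher number a weaker inhibitor), compound 3 gives 25000 nM, the lowest of the three numbers, but the step of a 1.1-fold lower number from compound 1 to compound 3 (0.03 log units; within the scatter) and the step of a 1.6-fold lower number from compound 2 to compound 3 (0.19 log units; within the scatter) both lie within the scatter, so the three compounds cannot be told apart in this assay.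

Compound 4 `COc1cc2nc(N3CCN(S(=O)(=O)c4ccc(-c5ccc(C)cc5)cc4)CC3)nc(N)c2cc1OC` carries the change (4-methylphenyl in place of trifluoromethoxy on an aromatic carbon). Going by the values given here, none of the measured steps swaps a small group for a second aromatic ring; the steps of a 1.4-fold higher number from compound 1 to compound 2 (0.16 log units; within the scatter) and a 1.6-fold lower number from compound 2 to compound 3 (0.19 log units; within the scatter) only show that small exchanges at this position left the number essentially unchanged. Given that, the expected step from compound 3 to compound 4 is a 1.3-fold lower number from compound 3 to compound 4 (0.10 log units; within the scatter), without clear direction. Compound 4 is therefore estimated at 20000 nM, with a plausible range from 6000 nM to 60000 nM.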

Compound 4, half-maximal inhibitory concentration: 3400 nM
Compound 4: middle estimate off by 5.9-fold (0.77 log units), on the high side; measured number below the stated range.
By their numbers in this assay, from the lowest: compound 4; then compounds 3, 1 and 2 (each within the scatter of the next).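

The position is not indifferent to what it carries: the exchanges among trifluoromethyl, methoxy and trifluoromethoxy stayed within the scatter, but 4-methylphenyl gives a 7.4-fold lower number from compound 3 to compound 4 (0.87 log units; beyond the scatter), a 7.9-fold lower number from compound 1 to compound 4 (0.90 log units; beyond the scatter) and an 11-fold lower number from compound 2 to compound 4 (1.06 log units; beyond the scatter), all beyond the scatter. Among these four compounds, the only clear shift comes with the entry of a second aromatic ring, although this rests on compound 4 alone. Nothing shown here explains why this change lowers the number.

Whether the step needs the methyl on the new ring, or an aromatic ring at all, stays open, since the compounds shown include neither a plain phenyl nor a cyclohexyl group. They also do not tell how the number would move with an amine or a carboxylic acid on the new ring in place of that methyl.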